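This account rests on a few compounds, and the source may have more. Where it says the series, first, only, none or still open, it means among the compounds named here.

Compound 1 `CSc1ccc(-c2nc3c(=O)n(C)c(=O)n(C)c3[nH]2)cc1` sits at the potent end of this small set. In an assay for binding affinity to adenosine receptor A1 (Bos taurus) (on this read-out higher numbers stand for weaker inhibition and lower numbers for stronger inhibition), compound 1 gives 2 nM. Compound 2 `C=CCn1c(=O)c2[nH]c(-c3ccc(Cl)cc3N)nc2n(C)c1=O` is measured in this assay as well, and there compound 2 gives 2 nM, so the two numbers sit level at the digits shown and within the usual scatter of each other; no order between them can be read from this.

Compound 3 `CCOc1ccc(-c2nc3c(=O)n(C)c(=O)n(C)c3[nH]2)cc1` has not yet been measured in this assay. It differs from compound 1 in one place: ethoxy in place of methylsulfanyl on an aromatic carbon. The change sits on an aromatic carbon of a six-membered aromatic ring of carbon only, para to a large group, and exchanges one small neutral group with a single hydrogen-bond acceptor for another of the same kind. Among the measured compounds shown here, no measured pair in this set carries this exact exchange, so there is nothing here to set the size of the step.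

Compound 3 is therefore expected to stay near compound 1, with a step of a 2.0-fold higher number from compound 1 to compound 3 (0.30 log units; within the scatter) that would be within or barely beyond the scatter. On that basis compound 3 is estimated at 4 nM, in a range from 1.5 nM to 12 nM.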

Compound 3, half-maximal inhibitory concentration: 2 nM
For compound 3 the middle estimate is 2.0-fold (0.30 log units) above the measured one, and the stated range covers the measured number.
By their numbers in this assay, from the lowest: compounds 1, 2 and 3 (each within the scatter of the next).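

In this assay, among the compounds shown here, the exchange of methylsulfanyl for ethoxy, on an aromatic carbon para to a large group, leaves no change at the digits printed from compound 1 to compound 3 (within the scatter) and gives the first reading of this position, since the earlier compounds offered no pair that differed in one place. The exchange replaces the sulfur-linked group of two heavy atoms with an oxygen-linked group of three, while the count of hydrogen-bond acceptors stays the same and no donor or charge enters, and the number in this assay does not shift beyond the scatter. At this place, then, the two groups cannot be told apart by this read-out, though a single pair says nothing about other groups here. Nothing shown here accounts for why the two groups read alike. On these data alone, what a longer chain such as butoxy, an amine or a carboxylic acid would do at this place remains open. As far as these compounds go, it is also open whether the same exchange would read alike on a core carrying other groups, such as the core of compound 2.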